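The compounds below may be only part of what the source reports. "The series", "measured", "known", "first", "only" and "open" are said of these compounds alone.

Compound 3 `COc1cc2c(cc1OC)C(CC(=O)N1CCCC1)CC2` stands lowest of the three compounds measured in a functional assay on the whole organism (strain Wistar) for inhibition, with Rattus norvegicus as the target, read by paw edema, with stated times of 60 min and 1 h, at a dose of 100 mg/kg by the oral route; on this read-out lower numbers stand for less inhibition and higher numbers for more inhibition at the one dose given (going by the name of the read-out). Compound 3 gives 4.69%, while compound 1 `CCNC(=O)CC1CCc2cc(OC)c(OC)cc21` gives 15.6% and compound 2 `COc1cc2c(cc1OC)C(CC(=O)NC1CCCCC1)CC2` gives 50%. The step is a number 10.9 percentage points lower from compound 1 to compound 3 (beyond the scatter), and the step is a number 45.3 percentage points lower from compound 2 to compound 3 (beyond the scatter), both beyond the scatter.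

Compound 4 `COc1cc2c(cc1OC)C(CC(=O)N1CCOCC1)CC2` differs from compound 3 in one place (morpholin-4-yl in place of pyrrolidin-1-yl on a carbonyl carbon). Among the compounds with values here, the steps that bear on this change are those at the same carbonyl carbon: a number 10.9 percentage points lower from compound 1 to compound 3 (beyond the scatter) was modest, and a number 45.3 percentage points lower from compound 2 to compound 3 (beyond the scatter) was large. Both tell that the amide nitrogen decides the size of the read-out here, but neither compares two ring-closed groups of this kind with each other, so the direction of the present change is not fixed by them. Compound 4 is therefore expected to sit close to compound 3, with a step of a number 4.3 percentage points higher from compound 3 to compound 4 (within the scatter) in this assay that is not expected to pass beyond the scatter. The estimate for compound 4 is 9%, in the range from 0% to 28%.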

Compound 4, a percentage reported as inhibition, in the whole organism at one dose (the size of the read-out at that dose, not a potency): 15.6%
The estimate for compound 4 lay 6.6 percentage points below the measured number; the measured number falls inside the stated range.
By their numbers in this assay, from the lowest: compound 3; then compounds 1 and 4 (each within the scatter of the next); then compound 2.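

Within the data shown here, the read-out of this assay shows a number 10.9 percentage points higher from compound 3 to compound 4 (beyond the scatter) as the first comparison of two ring-closed groups on this carbonyl carbon, so the choice of ring matters here, although ring size and the ring oxygen change together. Morpholin-4-yl gives a result level with the open ethylamino group, with no change at the digits printed from compound 1 to compound 4 (within the scatter) and it remains well short of cyclohexylamino, with a number 34.4 percentage points lower from compound 2 to compound 4 (beyond the scatter) so a ring-closed group on the amide nitrogen need not stand lowest among these compounds. Nothing measured here accounts for these steps.

Piperidin-1-yl, a six-membered ring without the oxygen, would be needed to tell ring size apart from the ring oxygen. On these data alone, it also remains open whether the high number belongs to cyclohexylamino alone or would extend to cyclopentylamino or benzylamino on the same carbonyl carbon.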